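The source may report more compounds than this note shows. Statements on the series, on what has been measured and on what is new or still open speak of the compounds shown alone.

Values so far in a functional assay on MCF7 cells (Homo sapiens) for inhibition; a higher number here means a weaker inhibitor, a lower number a stronger inhibitor:
- compound 1 `CCCCCC[C@@]1(C)SC(=O)C=C1OC` gives 14 ug/mL
- compound 2 `CCCCCC[C@@]1(C)SC(=O)C=C1OCCCCCl` gives 8.6 ug/mL
- compound 3 `C#CCOC1=CC(=O)S[C@]1(C)CCCCCC` gives 21.9 ug/mL

Compound 3 stands at 21.9 ug/mL in this set. The measured gaps to it are a 1.6-fold higher number from compound 1 to compound 3 (0.19 log units; within the scatter) and a 2.5-fold higher number from compound 2 to compound 3 (0.41 log units; beyond the scatter) in this series.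

Not yet measured is compound 4 `CCCCCC[C@@]1(C)SC(=O)C=C1OCC(=O)NCCCBr`, which has (3-bromopropyl)carbamoyl in place of ethynyl on a saturated chain carbon bound to an oxygen on an unsaturated carbon.

The same place has also given a 1.6-fold lower number from compound 1 to compound 2 (0.21 log units; within the scatter) here, so all three measured changes there are small. Within the data shown here, no measured compound carries the carbamoyl part, and that remains untested. The 3-chloropropyl group of compound 2 is the closest measured match to the 3-bromopropyl end. A slight shift to a lower number is therefore expected in this assay, with nothing beyond the scatter. The estimated step is a 1.6-fold lower number from compound 3 to compound 4 (0.19 log units; within the scatter) on this reasoning. For compound 4 the expected value is 14 ug/mL with an estimated range from 6 ug/mL to 32 ug/mL overall.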

Compound 4, half-maximal inhibitory concentration: 6.7 ug/mL
Beside the measured number, compound 4's estimate is 2.1-fold (0.32 log units) above it; measured number inside the range.
By their numbers in this assay, from the lowest: compounds 4, 2, 1 and 3 (each within the scatter of the next, the first and the last beyond it).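

In this assay this position now shows steps beyond the scatter against two of the earlier groups: a 3.3-fold lower number from compound 3 to compound 4 (0.51 log units; beyond the scatter) for the change from ethynyl and a 2.1-fold lower number from compound 1 to compound 4 (0.32 log units; beyond the scatter) for the change from hydrogen, both modest. Against the 3-chloropropyl group the (3-bromopropyl)carbamoyl group shows no separation, with a 1.3-fold lower number from compound 2 to compound 4 (0.11 log units; within the scatter), so this larger group with its carbamoyl part reads the same as the simple halogen-ended chain. No evidence at hand bears on these steps.

The compounds shown do not separate the contribution of the carbamoyl part from that of the 3-bromopropyl end. As far as these compounds go, whether a longer chain, or an amine in place of the bromine at the chain end, would hold the number at this level remains open.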